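Moving the fluorine on compound 1: notes toward compound 4

The source may report more compounds than this note shows. Statements on the series, on what has been measured and on what is new or still open speak of the compounds shown alone.

Measured in a functional assay on HeLa cells (Homo sapiens) for antiproliferative activity, read by CCK-8 assay, with a stated time of 72 h, tested at 8 uM; a lower number here means a weaker effect, a higher number a stronger effect of the compound at the concentration tested:
compound 1 `Nc1ccccc1NC(=O)c1ccc(CSC(=S)N2CCN(c3ccc(F)cc3)CC2)cc1` gives 64.5%
compound 2 `CC1CCCCN1C(=S)SCc1ccc(C(=O)Nc2ccccc2N)cc1` gives 76.3%
compound 3 `CCN(Cc1ccncc1)C(=S)SCc1ccc(C(=O)Nc2ccccc2N)cc1` gives 77.7%

Compound 1 stands lowest of the three numbers in this assay; compound 2 and compound 3 both lie beyond the scatter above it, while those two sit within the scatter of each other. Among the compounds with values here, the one measured step, a number 1.4 percentage points higher from compound 2 to compound 3 (within the scatter), exchanges the group on the thiocarbonyl carbon and leaves the fluorophenyl ring untouched, so it does not bear on the change considered here. Compound 4 `Nc1ccccc1NC(=O)c1ccc(CSC(=S)N2CCN(c3ccccc3F)CC2)cc1` differs from compound 1 by 2-fluorophenyl in place of 4-fluorophenyl on an amine nitrogen in a ring. Within the data shown here, no measured pair shows this change, so no step beyond the scatter is expected in this assay. Compound 4 is therefore expected near 67%, between 54% and 80%. The expected step of a number 2.5 percentage points higher from compound 1 to compound 4 (within the scatter) is estimated to fall within the scatter.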

Compound 4, a percentage reported as inhibition, at one concentration (the size of the read-out at that concentration, not a potency): 59.2%
For compound 4 the middle estimate is 7.8 percentage points above the measured one; the measured number falls inside the stated range.
By their numbers in this assay, from the lowest: compounds 4 and 1 (each within the scatter of the next); then compounds 2 and 3 (each within the scatter of the next).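

Exchanging 4-fluorophenyl for 2-fluorophenyl on the amine nitrogen in the ring gives, in this assay, a number 5.3 percentage points lower from compound 1 to compound 4 (within the scatter). Within the data shown here, this is the first reading of this position, and at the concentration tested it does not separate the two fluorine placements. No supporting evidence bears on this result.

Open, going by these compounds, is whether a phenyl without fluorine, or one carrying a methoxy group or a carboxylic acid, would read alike in this assay. Also open, on these data alone, is whether the two placements stay inseparable at other concentrations.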